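The source may report more compounds than this note shows. Statements on the series, on what has been measured and on what is new or still open speak of the compounds shown alone.

Three analogues sharing one core have been run in a functional assay on HEK293 cells for agonist activity at Bombesin receptor subtype-3 (Mus musculus), read by luminescence and calcium flux, with a stated time of 10 min; a lower number here means that less compound is needed, a higher number that more compound is needed for the effect. Compound 1 `CCC(C)(C)Cc1c[nH]c(CCc2ccc(-c3cnccn3)cc2)n1` gives 107 nM. Compound 2 `CCC(C)(C)Cc1c[nH]c(CCc2ccc(-c3cccnc3)cc2)n1` gives 97 nM. Compound 3 `CCC(C)(C)Cc1c[nH]c(CCc2ccc(N3CCCCC3)cc2)n1` gives 133 nM, the highest of the three numbers, though within the usual scatter of compound 1 and compound 2. The two steps leading to it, a 1.2-fold higher number from compound 1 to compound 3 (0.09 log units; within the scatter) and a 1.4-fold higher number from compound 2 to compound 3 (0.14 log units; within the scatter), show that exchanging the group on this aromatic carbon has so far left the number essentially unchanged. Compound 4 `CCC(C)(C)Cc1c[nH]c(CCc2ccc(-n3ccnn3)cc2)n1` carries the next such exchange: 1H-1,2,3-triazol-1-yl in place of piperidin-1-yl on an aromatic carbon. With both earlier exchanges on the aromatic carbon inside the scatter, compound 4 is expected to show a step of a 1.2-fold lower number from compound 3 to compound 4 (0.06 log units; within the scatter), none beyond the scatter. Compound 4 is therefore estimated at 115 nM, between 50 nM and 260 nM.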

Compound 4, half-maximal effective concentration: 111 nM
The estimate for compound 4 lay 1.0-fold (0.02 log units) above the measured number, within the range that was stated.
By their numbers in this assay, from the lowest: compounds 2, 1, 4 and 3 (each within the scatter of the next).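

In this assay, the 1H-1,2,3-triazol-1-yl group on this aromatic carbon stays within the scatter of all three earlier groups (a 1.2-fold lower number from compound 3 to compound 4 (0.08 log units; within the scatter); a 1.1-fold higher number from compound 2 to compound 4 (0.06 log units; within the scatter); a 1.0-fold higher number from compound 1 to compound 4 (0.02 log units; within the scatter)). The exchange for piperidin-1-yl replaces a six-membered non-aromatic ring with a five-membered aromatic ring and 1 hydrogen-bond acceptor with 3 hydrogen-bond acceptors, yet the number does not shift beyond the scatter. No supporting evidence bears on this result. As far as these compounds go, it remains open whether a carboxylic acid, a primary amine or a single fluorine at this position would move the number beyond the scatter. The compounds shown also leave open how changes elsewhere on the shared core would behave.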